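The source may hold more compounds than are shown below. What is called first, only, known or untested is meant among the compounds shown, and "the series" means these compounds.

The measured compounds and their values:

Compound 1, `O=c1ccn(Cc2ncnc3c2ncn3[C@@H]2O[C@H](CO)[C@@H](O)[C@H]2O)cc1`, gives > 100000 nM in a functional assay on Huh-7 cells (Homo sapiens) for cytotoxicity, read by MTT assay, with a stated time of 3 days (on this read-out lower numbers stand for higher toxicity in this test and higher numbers for lower toxicity in this test), which is a limit of the assay rather than a number.
Compound 2, `CC(=O)N(Cc1ncnc2c1ncn2[C@@H]1O[C@H](CO)[C@@H](O)[C@H]1O)C1CCCCC1`, gives > 100000 nM in this assay, again a limit of the assay.
Compound 3, `CC(=O)N(Cc1ccccc1)Cc1ncnc2c1ncn2[C@@H]1O[C@H](CO)[C@@H](O)[C@H]1O`, gives > 100000 nM in this assay, also a limit of the assay.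

Compound 1 therefore stands at a limit, with the two other values shown also limits, so nothing places it above or below them. Among the measured compounds shown here, the only step between measured compounds, a step that the two limits leave unreadable from compound 2 to compound 3, cannot be read, since both ends are limits. What the three values share is the limit of > 100000 nM in this assay, at which 3 of the 3 values shown sit.

Compound 4, `OC[C@H]1O[C@@H](n2cnc3c(CN4CCCCC4)ncnc32)[C@H](O)[C@@H]1O`, differs from compound 1 by a group of 6 heavy atoms (5 carbon, 1 nitrogen; one six-membered non-aromatic ring with 1 hetero atom) in place of a group of 7 heavy atoms (5 carbon, 1 nitrogen, 1 oxygen; one six-membered aromatic ring with 1 hetero atom), on a saturated chain carbon bound to an aromatic carbon. For the measured compounds named here, no measured step bears directly on this change, and the single step available gives no size. The account therefore rests on the limit of > 100000 nM in this assay, at which 3 of the 3 values shown sit, alone. Compound 4 is expected to sit at the same limit, so that a number no higher from compound 1 to compound 4 (the limit leaves the size open) is estimated to lie within the scatter. The estimate for compound 4 in this assay is 100000 nM, with a range from 30000 nM to 300000 nM.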

Compound 4, half-maximal cytotoxic concentration: 87000 nM
Compound 4: middle estimate off by 1.1-fold (0.06 log units), on the high side, and the stated range covers the measured number.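

In this assay compound 4 gives 87000 nM, the first value among the compounds shown that is a number and not a limit of the assay. Piperidin-1-yl on a saturated chain carbon bound to an aromatic carbon thus gives a readable toxicity value at this position, with an at least 1.1-fold lower number from compound 1 to compound 4 (0.06 log units; that floor lies within the scatter). Compound 1 stands at a limit, so the true size of this step stays open and it may not exceed the scatter, and the set as a whole still clusters at one point: the limit of > 100000 nM in this assay, at which 3 of the 4 values shown sit.

The compounds shown leave open whether a morpholin-4-yl ring or an open-chain diethylamino group on the same carbon would also give a number in this assay. They also leave open how far the value of compound 4 depends on the piperidin-1-yl ring itself.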